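This account rests on a few compounds, and the source may have more. Where it says the series, first, only, none or still open, it means among the compounds named here.

Compound 1 `S=C(N/N=C/c1ccc2ccccc2n1)Nc1cccc(Br)c1` was measured in a functional assay on HeLa cells (Homo sapiens) for antiproliferative activity, read by sulforhodamine B assay, with a stated time of 72 h (a higher number here means a weaker inhibitor, a lower number a stronger inhibitor), where compound 1 gives 70000 nM. Within the data shown here, this is the only actual number in the set, so compound 1 stands as the sole compound with a measured value rather than a limit. Compound 2 `Cc1ccc(NC(=O)N/N=C/c2ccc3ccccc3n2)cc1` in this assay reaches only > 100000 nM, which is a limit of the assay and not a number. The other value in the set is thus the limit described as the limit of > 100000 nM in this assay, at which 1 of the 2 values shown sits.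

Compound 3 `Fc1cccc(NC(=S)N/N=C/c2ccc3ccccc3n2)c1` has not yet been measured. It differs from compound 1 in a single place: fluoro in place of bromo on an aromatic carbon. Among the measured compounds shown here, no measured pair in the set shows what this swap of one halogen for another at the same place does, so there is no step to lean on. The change is small, and the step from compound 1 to compound 3 is expected to be a 1.2-fold higher number from compound 1 to compound 3 (0.08 log units; within the scatter), that is, within the scatter of this assay, with some chance of drifting weaker. Compound 3 is therefore expected to give 85000 nM, with a likely range from 30000 nM to 200000 nM.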

Compound 3, half-maximal inhibitory concentration: 70100 nM
The estimate for compound 3 lay 1.2-fold (0.08 log units) above the measured number; the range from low to high includes it.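

In this assay, the change from 3-bromophenyl to 3-fluorophenyl gives a 1.0-fold higher number from compound 1 to compound 3 (0.00 log units; within the scatter). Until now a single number stood alone, and nothing showed whether this place on the ring responds to the choice of halogen; this pair provides the first reading, and bromo and fluoro cannot be told apart here, with both compounds remaining weak inhibitors in this measurement. The only other result shown marks the upper end of the scale, and compound 2 has no actual number, only a limit of the assay: the limit of > 100000 nM in this assay, at which 1 of the 3 values shown sits.

Going by these compounds, whether this flat response extends beyond these two halogens remains open, since a single pair cannot show how an amine, a methoxy group or a carboxylic acid at the same place would behave. Also unresolved is what a single change elsewhere in the shared core would do, and compound 2 cannot settle this, as it differs from compound 1 in more than one place.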